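From 3-(dimethylamino)propyl to 3-hydroxypropyl on the shared core

The source may hold more compounds than are shown below. What is called first, only, known or untested is meant among the compounds shown, and "the series" means these compounds.

Measured so far in a functional assay on K562 cells (Homo sapiens) for antiproliferative activity, read by MTT assay, with a stated time of 48 h; on this read-out higher numbers stand for weaker inhibition and lower numbers for stronger inhibition:
- compound 1 `Cn1c(N)c(-c2nc3ccccc3[nH]2)c2nc(C#N)c(C#N)nc21`: > 50000 nM (a limit of the assay)
- compound 2 `CN(C)CCn1c(N)c(-c2nc3ccccc3[nH]2)c2nc(C#N)c(C#N)nc21`: 6340 nM
- compound 3 `CN(C)CCCn1c(N)c(-c2nc3ccccc3[nH]2)c2nc(C#N)c(C#N)nc21`: 1730 nM

Compound 3 stands lowest of the series, and compound 2 lies above it, with a 3.7-fold lower number from compound 2 to compound 3 (0.56 log units; beyond the scatter). Compound 1 sits at the limit of > 50000 nM in this assay, at which 1 of the 3 values shown sits.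

Compound 4 `N#Cc1nc2c(-c3nc4ccccc4[nH]3)c(N)n(CCCO)c2nc1C#N` carries hydroxy in place of dimethylamino, on a saturated chain carbon, three bonds along the chain from an aromatic nitrogen: hydroxy in place of dimethylamino on a saturated chain carbon, three bonds along the chain from an aromatic nitrogen. Among the compounds with values here, no measured step removes dimethylamino while keeping the chain, so the evidence is indirect. The closest guides are an at least 7.8-fold lower number from compound 1 to compound 2 (0.89 log units; beyond the scatter) and an at least 28-fold lower number from compound 1 to compound 3 (1.46 log units; beyond the scatter), both of which bring in a dimethylamino-bearing chain and are beyond the scatter.

A modest to large step towards a higher number is therefore expected in this assay, though compound 4 keeps the chain that compound 1 lacks. The estimated change is an 8.1-fold higher number from compound 3 to compound 4 (0.91 log units; beyond the scatter). For compound 4 the expected value is 14000 nM, with an estimated range from 4000 nM to 50000 nM.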

Compound 4, half-maximal inhibitory concentration: > 50000 nM
Compound 4: a limit, no number; the forecaster's own chance of this, stated with the estimate: 25%; middle value at least 3.5-fold (0.55 log units) away from the limit.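

In this assay, with compound 4 at a limit of the assay, hydroxy in place of dimethylamino on a saturated chain carbon, three bonds along the chain from an aromatic nitrogen, gives an at least 28-fold higher number from compound 3 to compound 4 (1.46 log units; beyond the scatter). Compound 2, with its shorter dimethylamino chain, also keeps a clear margin over compound 4, with an at least 7.8-fold higher number from compound 2 to compound 4 (0.89 log units; beyond the scatter). Among the compounds shown, the 3-hydroxypropyl chain alone does not bring the lower numbers seen with compound 2 and compound 3, which both end in dimethylamino.

The step between compound 1 and compound 4 cannot be read: the limit of > 50000 nM in this assay, at which 2 of the 4 values shown sit.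

Still open, from the compounds shown here alone, is whether another amine at the chain end, such as a primary amine or pyrrolidine, or a longer chain ending in dimethylamino, would keep or lower the number reached by compound 3.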